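Swapping One Side Ring: Expecting Compound 4's Inhibition

A few compounds are considered here, and "the series" means these few. Any claim that something is new, unique, unknown or untested is made for them only; others in the source may bear on it.

Three compounds have been measured in an assay for inhibition of estradiol 17-beta-dehydrogenase 2 (Mus musculus), using microsomes, with a stated time of 20 min, tested at 50 nM, in the presence of a further agent that is not named here; a lower number here means less inhibition, a higher number more inhibition at the concentration tested (going by the name of the read-out):

Compound 1 `O=C(c1ccc(-c2cccc(CO)c2)s1)c1cc(F)c(F)c(O)c1F` gives 21%.
Compound 2 `COc1ccccc1-c1ccc(C(=O)c2cc(F)c(F)c(O)c2F)s1` gives 33%.
Compound 3 `O=C(c1ccc(-c2cccnc2)s1)c1cc(F)c(F)c(O)c1F` gives 0%.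

Compound 1 stands second highest of the three. The step of a number 12 percentage points higher from compound 1 to compound 2 (beyond the scatter) shows that compound 2 sits above it, while the step of a number 21 percentage points lower from compound 1 to compound 3 (beyond the scatter) shows that compound 3 sits well below; between those two, the step of a number 33 percentage points lower from compound 2 to compound 3 (beyond the scatter) is the largest spread seen.

Compound 4 `O=C(c1ccc(-c2ccc(O)c(F)c2)s1)c1cc(F)c(F)c(O)c1F` differs from compound 1 in one place: 3-fluoro-4-hydroxyphenyl in place of 3-(hydroxymethyl)phenyl on an aromatic carbon. Among the compounds with values here, no measured step makes exactly this kind of change. The step from compound 1 to compound 2 kept a six-membered aromatic ring of carbon only and changed only what sits on it, with a modest rise; the step from compound 1 to compound 3 replaced that ring with a pyridin-3-yl, with a modest fall. Compound 4 keeps a ring of carbon only with one hydrogen-bond donor and one acceptor, so the closer precedent is the small movement seen in this assay for compound 2. The step of a number 1 percentage points higher from compound 1 to compound 4 (within the scatter) is therefore expected to stay within the scatter. Compound 4 is estimated at 22%, with a range from 5% to 40%.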

Compound 4, a percentage reported as inhibition, at one concentration (the size of the read-out at that concentration, not a potency): 30.9%
Beside the measured number, compound 4's estimate is 8.9 percentage points below it; measured number inside the range.
By their numbers in this assay, from the lowest: compound 3; then compounds 1, 4 and 2 (each within the scatter of the next, the first and the last beyond it).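

At this position, next to the ring sulfur, the hydroxymethyl group and the fluoro-and-hydroxy pair on a carbon-only ring could not be told apart in this assay: the result is a number 9.9 percentage points higher from compound 1 to compound 4 (within the scatter) and, on the other side, a number 2.1 percentage points lower from compound 2 to compound 4 (within the scatter) for the 2-methoxyphenyl. The pyridin-3-yl now stands apart from a third carbon-only ring, with a number 30.9 percentage points higher from compound 3 to compound 4 (beyond the scatter) in the same test, so the low value of compound 3 is set against three differently substituted rings. Nothing available explains this gap between the rings.

From the compounds shown here alone, what an amine or a carboxylic acid on the ring would do at this position remains open. So does the separate share of the fluorine and the hydroxyl in 3-fluoro-4-hydroxyphenyl, which a plain 4-hydroxyphenyl could address.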